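The source may report more compounds than this note shows. Statements on the series, on what has been measured and on what is new or still open speak of the compounds shown alone.

In an ADME assay on HepG2 2.2.15 cells (Homo sapiens) for cytotoxicity, read by MTT assay (a higher number here means that more compound is tolerated, a lower number that less compound is tolerated), compound 1 `C=C1CC[C@@H]2[C@](C)(COC(=O)c3ccco3)[C@H](O)CC[C@@]2(C)[C@@H]1/C=C/C1=CCOC1=O` gives 92000 nM and compound 2 `C=C1CC[C@@H]2[C@](C)(COC(=O)c3cc(=O)c4ccccc4o3)[C@H](O)CC[C@@]2(C)[C@@H]1/C=C/C1=CCOC1=O` gives 171000 nM. These two values lie within the scatter of each other, so compound 1 cannot be placed apart from compound 2. Compound 3 `C=C1CC[C@@H]2[C@](C)(COC(=O)c3ccco3)[C@H](OC(=O)c3ccco3)CC[C@@]2(C)[C@@H]1/C=C/C1=CCOC1=O` differs from compound 1 in one place: (furan-2-yl)carbonyl in place of hydrogen on an oxygen on a saturated carbon. In words, (furan-2-yl)carbonyl stands in place of hydrogen on an oxygen on a saturated carbon, turning hydroxy into ((furan-2-yl)carbonyl)oxy. Within the data shown here, only one measured step bears on this, and only loosely: a 1.9-fold higher number from compound 1 to compound 2 (0.27 log units; within the scatter). Among the measured compounds shown here, that step exchanged a group on a carbonyl carbon and stayed within the scatter, while no measured compound tests a change on the free hydroxy. For the measured compounds named here, with only that guide, no step beyond the scatter is expected in this assay. The expected change is a 1.2-fold lower number from compound 1 to compound 3 (0.06 log units; within the scatter). The estimated value for compound 3 is 80000 nM, within a range of 30000 nM to 200000 nM.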

Compound 3, half-maximal cytotoxic concentration: 1110000 nM
Compound 3: the middle estimate sits 14-fold (1.14 log units) below what was measured; measured number outside the range, above it.
By their numbers in this assay, from the lowest: compounds 1 and 2 (each within the scatter of the next); then compound 3.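

In this assay, (furan-2-yl)carbonyl in place of hydrogen on an oxygen on a saturated carbon gives a 12-fold higher number from compound 1 to compound 3 (1.08 log units; beyond the scatter), so far more compound is tolerated once hydroxy becomes ((furan-2-yl)carbonyl)oxy. Among these compounds, this is the first change here to lie beyond the scatter, whereas the exchange of groups on a carbonyl carbon gave a 1.9-fold higher number from compound 1 to compound 2 (0.27 log units; within the scatter), which stayed within it. No measurement at hand explains this rise.

The compounds shown leave open whether the rise depends on the furan ring or would also follow from a smaller acetyl group on this oxygen. They also leave open whether a carbonyl is needed at all, which a methyl group on the same oxygen would test.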